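Swapping dimethylamino for acetyl on an aryl ring

The source may hold more compounds than are shown below. What is called first, only, known or untested is meant among the compounds shown, and "the series" means these compounds.

Going by the values given here, compound 1 `COc1cc(C)cc(-c2c(-c3ccnc(-c4ccc(N(C)C)cc4)c3)cnn2CC#N)c1` is one of two compounds measured so far in a functional assay on CAKI-1 cells (Homo sapiens) for inhibition, read by sulforhodamine B assay, with a stated time of 48 h; a higher number here means a weaker inhibitor of growth, a lower number a stronger inhibitor of growth. In that assay compound 1 gives 36.9 nM, the lowest number of the pair. Among the compounds with values here, compound 2 `Cc1cc(O)cc(-c2nn(CC#N)cc2-c2ccnc(-c3ccc(Oc4ccccc4)cc3)c2)c1` differs from compound 1 in more than one place, so no single step between them can be read; in this assay compound 2 gives 1800 nM, and the gap between the two values is far beyond the usual scatter.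

Compound 3 `COc1cc(C)cc(-c2c(-c3ccnc(-c4ccc(C(C)=O)cc4)c3)cnn2CC#N)c1` has not yet been measured. It differs from compound 1 in one place: acetyl in place of dimethylamino on an aromatic carbon. Within the data shown here, no measured pair in this set isolates this kind of change, so there is no direct precedent to lean on. Since the group that leaves and the group that enters are of the same size and the rest of the structure is untouched, the expected step from compound 1 to compound 3 is a 2.4-fold higher number from compound 1 to compound 3 (0.39 log units; beyond the scatter), a modest weakening that may well stay within the scatter. For compound 3 the estimate in this assay is 90 nM, with a range from 30 nM to 300 nM.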

Compound 3, concentration for 50% growth inhibition: 4240 nM
Beside the measured number, compound 3's estimate is 47-fold (1.67 log units) below it, outside the stated range (above it).
By their numbers in this assay, from the lowest: compound 1; then compound 2; then compound 3.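

In this assay, acetyl in place of dimethylamino on an aromatic carbon, para to a large group, gives a 110-fold higher number from compound 1 to compound 3 (2.06 log units; beyond the scatter), so this position is far from indifferent to the group it carries. Counting atoms does not predict this outcome: the group that leaves and the group that enters each have 3 heavy atoms, 0 hydrogen-bond donors, 1 hydrogen-bond acceptor and no net charge, and they differ in nitrogen against oxygen and in the double bond of acetyl. Nothing measured here shows what lies behind a step of this size.

Going by these compounds alone, with only this one pair, it remains open whether acetyl is especially poor at this position or dimethylamino is especially good, and a simpler amine such as methylamino, a carboxylic acid or a longer chain such as diethylamino in the same place would help separate the two readings. Compound 2 differs from each of the other two compounds in more than one place, so its steps cannot be read and it does not settle the question.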